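Bromo for chloro in a series at the limit

A few compounds are considered here, and "the series" means these few. Any claim that something is new, unique, unknown or untested is made for them only; others in the source may bear on it.

Measured in a functional assay on KB cells (Homo sapiens) for inhibition (on this read-out higher numbers stand for weaker inhibition and lower numbers for stronger inhibition), so far:
- Compound 1 `Clc1ccc(Cn2c(Cl)nc3cc(Cl)c(Cl)cc32)cc1` gives > 100000 nM as a limit of the assay
- Compound 2 `Clc1ccc(Cn2c(Cl)nc3cc(Cl)c(Cl)cc32)cc1Cl` gives > 100000 nM as a limit of the assay
- Compound 3 `CC(C)(C)c1ccc(Cn2c(Cl)nc3cc(Cl)c(Cl)cc32)cc1` gives > 100000 nM as a limit of the assay

Compound 2 has no numerical value, only the limit > 100000 nM as its result, and the same holds for the two other compounds. This is summed up by the limit of > 100000 nM in this assay, at which 3 of the 3 values shown sit, in the data so far.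

The next compound is compound 4 `Clc1ccc(Cn2c(Br)nc3cc(Cl)c(Cl)cc32)cc1Cl`, which differs from compound 2 by bromo in place of chloro on an aromatic carbon in the core: bromo in place of chloro on an aromatic carbon, between two ring nitrogen atoms.

Among the compounds with values here, two measured steps bear on this, and neither has a size: a step that the two limits leave unreadable from compound 1 to compound 2 and a step that the two limits leave unreadable from compound 1 to compound 3 are the only ones available. Neither is a bromo for chloro change. No size can be carried over, so no step beyond the scatter is expected in either direction in this assay for this change.

The expected change is a number no higher from compound 2 to compound 4 (the limit leaves the size open) on this estimate. Compound 4 is expected to stay close to the limit, with an estimated 100000 nM as the middle and an estimated range from 30000 nM to 200000 nM in this read-out.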

Compound 4, half-maximal inhibitory concentration: > 100000 nM
Compound 4: only a limit was reported; the forecaster's own chance of this, stated with the estimate: 75%; the middle value lies on the limit itself.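

In this assay compound 4 gives > 100000 nM, a limit of the assay. Within the data shown here, compound 2 is also reported only as a limit, so no step between compound 2 and compound 4 can be read. The compounds shown leave open whether bromo in place of chloro changes inhibition at all, as every result sits at one value: the limit of > 100000 nM in this assay, at which 4 of the 4 values shown sit.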